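Methyl to Benzyl on the Piperazine Chain

The source may report more compounds than this note shows. Statements on the series, on what has been measured and on what is new or still open speak of the compounds shown alone.

Compound 1, `Cn1c(-c2ccc(NC(=O)CCl)cc2)nc(-c2ccccc2)c1-c1ccccc1`: 42.8%
Compound 2, `Cn1ccnc1SCC(=O)Nc1ccc(-c2nc(-c3ccccc3)c(-c3ccccc3)n2C)cc1`: 43.4%
Compound 3, `CN1CCN(CC(=O)Nc2ccc(-c3nc(-c4ccccc4)c(-c4ccccc4)n3C)cc2)CC1`: 46.2%

These three numbers all come from a functional assay on MCF7 cells (Homo sapiens) for cytotoxicity, read by MTT assay, with a stated time of 24 h, tested at 32 ug/mL; a higher number here means a stronger effect of the compound at the concentration tested, a lower number a weaker effect. Compound 3 has the highest of the three, but its gap to compound 2, a number 2.8 percentage points higher from compound 2 to compound 3 (within the scatter), and to compound 1, a number 3.4 percentage points higher from compound 1 to compound 3 (within the scatter), both lie within the scatter, as does a number 0.6 percentage points higher from compound 1 to compound 2 (within the scatter). Put plainly, three different groups on the saturated chain carbon bound to the carbonyl carbon gave numbers that cannot be told apart.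

Compound 4, `Cn1c(-c2ccc(NC(=O)CN3CCN(Cc4ccccc4)CC3)cc2)nc(-c2ccccc2)c1-c1ccccc1`, keeps the whole of compound 3 and adds one change: phenyl in place of hydrogen on a saturated chain carbon bound to an amine nitrogen in a ring. Among the measured compounds shown here, no measured step touches this exact position, but the three steps above all sit on the same chain and none moved beyond the scatter. On that basis the step from compound 3 to compound 4 is expected to be a number 0.2 percentage points lower from compound 3 to compound 4 (within the scatter), a change no larger than the scatter. In this assay compound 4 is therefore estimated at 46%, with a likely range from 35% to 57%.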

Compound 4, a percentage reported as activity, at one concentration (the size of the read-out at that concentration, not a potency): 33.6%
Compound 4: middle estimate off by 12.4 percentage points, on the high side; the measured number lies below the stated range.
By their numbers in this assay, from the lowest: compounds 4, 1, 2 and 3 (each within the scatter of the next, the first and the last beyond it).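

Adding phenyl on the saturated chain carbon bound to an amine nitrogen in a ring, which turns methyl into benzyl, gives a number 12.6 percentage points lower from compound 3 to compound 4 (beyond the scatter) in this assay. This is the first single change among these compounds to move the number beyond the scatter, so this place on the molecule responds to change, and here the added aromatic ring goes with a weaker effect at the tested concentration. Nothing available explains the drop.

A single step cannot show whether the drop belongs to the aromatic ring itself or simply to the added carbon atoms. An ethyl or a cyclohexylmethyl group in the same place would help separate the two, while a benzyl group carrying a fluorine on its ring would test whether the ring tolerates substitution.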